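From Furan-2-yl to Thiophen-2-yl on a Carbonyl Carbon

A few compounds are considered here, and "the series" means these few. Any claim that something is new, unique, unknown or untested is made for them only; others in the source may bear on it.

The three measured compounds were tested in an assay on CHO cells for displacement of a labelled ligand from adenosine receptor A3 (Homo sapiens); on this read-out higher numbers stand for weaker inhibition and lower numbers for stronger inhibition:

compound 1, `CCNC(=O)[C@H]1O[C@@H](n2cnc3c(NNC(=O)c4ccc(C)o4)ncnc32)[C@H](O)[C@@H]1O`, gives > 5000 nM, a limit of the assay and not a number.
compound 2, `CCNC(=O)[C@H]1O[C@@H](n2cnc3c(NNC(=O)c4ccccc4)nc(Cl)nc32)[C@H](O)[C@@H]1O`, gives > 5000 nM, again only a limit.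
compound 3, `CCNC(=O)[C@H]1O[C@@H](n2cnc3c(NNC(=O)c4ccco4)nc(Cl)nc32)[C@H](O)[C@@H]1O`, gives > 5000 nM, once more a limit.

Compound 3 therefore stands nowhere in particular: its result in this assay is a limit, and the other two results shown are limits as well, so no ordering among them can be read. For the measured compounds named here, the one step that could be followed, a step that the two limits leave unreadable from compound 2 to compound 3, is left unreadable by the two limits. Going by the values given here, the only evidence on the measured steps is the limit of > 5000 nM in this assay, at which 3 of the 3 values shown sit.

Compound 4, `CCNC(=O)[C@H]1O[C@@H](n2cnc3c(NNC(=O)c4cccs4)nc(Cl)nc32)[C@H](O)[C@@H]1O`, differs from compound 3 by thiophen-2-yl in place of furan-2-yl on a carbonyl carbon. Among the compounds with values here, since the closest comparable step, from phenyl to furan-2-yl, was itself unreadable, and every value shown sits at the limit, there is no measured step from which a direction or a size for this assay can be taken. Compound 4 is therefore expected to remain at or beyond the limit, with a step that the limit leaves unreadable from compound 3 to compound 4 as the step this estimate implies. The estimated value for compound 4 in this assay is 8000 nM, in the range from 2000 nM to 30000 nM.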

Compound 4, inhibition constant: > 5000 nM
Compound 4: a limit, no number; the forecaster's own chance of this, stated with the estimate: 80%; the middle value does not contradict the limit.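

Compound 4 gives only a limit in this assay, as do compound 2 and compound 3, so neither step to compound 4 can be read: the limit of > 5000 nM in this assay, at which 4 of the 4 values shown sit. The compounds shown leave open whether phenyl, furan-2-yl and thiophen-2-yl on the carbonyl carbon differ at all in this read-out.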